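From 2-methoxyphenyl to 4-hydroxyphenyl: a small expected step

This account rests on a few compounds, and the source may have more. Where it says the series, first, only, none or still open, it means among the compounds named here.

Of the compounds shown here, two with a shared core have been measured in a functional assay on KB cells (Homo sapiens) for cytotoxicity; a lower number here means that less compound is needed, a higher number that more compound is needed for the effect. Compound 1 `COC1=C(C)C(=O)/C(=C(O)/C=C/c2ccc(Br)cc2)C(=O)C1(C)C` gives 1.9 ug/mL, and compound 2 `COC1=C(C)C(=O)/C(=C(O)/C=C/c2ccccc2OC)C(=O)C1(C)C` gives 2.8 ug/mL. These two values lie within the scatter of each other, so the numbers do not separate compound 2 from compound 1.

The next compound, compound 3 `COC1=C(C)C(=O)/C(=C(O)/C=C/c2ccc(O)cc2)C(=O)C1(C)C`, keeps the core and differs from compound 2 in one group: 4-hydroxyphenyl in place of 2-methoxyphenyl on a double-bonded chain carbon bound to a double-bonded chain carbon. Here 4-hydroxyphenyl stands in place of 2-methoxyphenyl on a double-bonded chain carbon bound to a double-bonded chain carbon.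

Among the compounds with values here, only one measured step bears on this change, since it exchanged a group at the same place: a 1.5-fold higher number from compound 1 to compound 2 (0.17 log units; within the scatter). Neither measured compound carries 4-hydroxyphenyl, so the data offer no direct test of that group, and the expectation stays wide. With so small a precedent, no clear change is expected in this assay, and the expected result is a 1.1-fold lower number from compound 2 to compound 3 (0.05 log units; within the scatter). For compound 3 the estimated value is 2.5 ug/mL, with an expected range from 1 ug/mL to 6 ug/mL.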

Compound 3, concentration for half-maximal effect: 3 ug/mL
The estimate for compound 3 lay 1.2-fold (0.08 log units) below the measured number, and the stated range covers the measured number.
By their numbers in this assay, from the lowest: compounds 1, 2 and 3 (each within the scatter of the next).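

In this assay, the change to 4-hydroxyphenyl gives a 1.1-fold higher number from compound 2 to compound 3 (0.03 log units; within the scatter). The entering group counts a hydrogen-bond donor that 2-methoxyphenyl lacks, yet this exchange does not separate the two compounds. The direct exchange of hydroxy for bromo on an aromatic carbon gives a 1.6-fold higher number from compound 1 to compound 3 (0.20 log units; within the scatter), so all three aromatic groups at this place on a double-bonded chain carbon now lie within the scatter of each other, and no data here explain that result.

From the compounds shown here alone, all three compounds still carry a substituted phenyl ring at this place, so it remains open whether an amine or a carboxylic acid on that ring, or a longer chain in place of the ring, would move the number beyond the scatter. The step from 2-methoxyphenyl to 4-hydroxyphenyl also alters both the group and where it stands on the ring, and a compound with 4-methoxyphenyl would be needed to tell those two changes apart.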